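The compounds below may be only part of what the source reports. "The series", "measured", "known", "first", "only" and "open" are said of these compounds alone.

Values measured so far in an ADME assay on L6 cells (Rattus norvegicus) for cytotoxicity; on this read-out lower numbers stand for stronger inhibition and higher numbers for weaker inhibition 
- compound 1 `O=C(CN1CCCC1)OC1CC2(N3CCCC3)CC(c3ccccc3)C1C(c1ccccc1)C2` gives 42900 nM 
- compound 2 `O=C(CCN1CCCC1)OC1CC2(N3CCCC3)CC(c3ccccc3)C1C(c1ccccc1)C2` gives 21900 nM 
- compound 3 `CN(C)C12CC(OC(=O)CCN3CCCCC3)C(C(c3ccccc3)C1)C(c1ccccc1)C2` gives 25800 nM 

The number for compound 3 lies within the usual scatter of those for compound 1 and compound 2, so these values set no order among the three.

Compound 4 `O=C(CCN1CCCCC1)OC1CC2(N3CCCC3)CC(c3ccccc3)C1C(c1ccccc1)C2` has not been measured yet. It differs from compound 3 in one place, with pyrrolidin-1-yl in place of dimethylamino on a saturated ring carbon. The count for this change reads pyrrolidin-1-yl in place of dimethylamino on a saturated ring carbon and nothing else in the structure differs.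

Among the compounds with values here, no measured step covers this swap directly. Within the data shown here, the only step available is a 2.0-fold lower number from compound 1 to compound 2 (0.29 log units; within the scatter) and it concerns a chain carbon bound to a carbonyl carbon, not this ring carbon. Closer evidence comes from compound 2, which already has pyrrolidin-1-yl on that ring carbon and gives 21900 nM in this assay while also differing from compound 3 in its chain, where it has pyrrolidin-1-yl instead of piperidin-1-yl. Its value lies within the scatter of that of compound 3, so no change beyond the scatter is expected, in either direction.

The expected step is a 1.1-fold lower number from compound 3 to compound 4 (0.05 log units; within the scatter) and it stays within the scatter. For compound 4 the estimated value is 23000 nM with an expected range from 11500 nM to 46000 nM in this read-out.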

Compound 4, half-maximal inhibitory concentration: 17800 nM
For compound 4 the middle estimate is 1.3-fold (0.11 log units) above the measured one; low and high end bracket the measured number.
By their numbers in this assay, from the lowest: compounds 4, 2, 3 and 1 (each within the scatter of the next, the first and the last beyond it).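

In this assay, within the data shown here, putting pyrrolidin-1-yl where dimethylamino stood on the saturated ring carbon gives a 1.4-fold lower number from compound 3 to compound 4 (0.16 log units; within the scatter) and is the first direct reading of this swap, so this ring carbon carries either amine without a difference that can be told from ordinary repeat variation. Among these compounds, on the chain, piperidin-1-yl in place of pyrrolidin-1-yl gives a 1.2-fold lower number from compound 2 to compound 4 (0.09 log units; within the scatter) and adds no separable effect of that ring swap, whereas (piperidin-1-yl)methyl in place of pyrrolidin-1-yl on the chain carbon bound to the carbonyl carbon gives a 2.4-fold lower number from compound 1 to compound 4 (0.38 log units; beyond the scatter) as the only step here that clears the scatter, and only modestly. Nothing available explains why these numbers fall as they do.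

The compounds shown leave open whether a morpholin-4-yl group or a primary amine on this ring carbon would also stay within the scatter of dimethylamino and pyrrolidin-1-yl. They also leave open whether a longer chain between the carbonyl and the piperidin-1-yl group would take the number further from that of compound 1 or leave it where it is.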